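The source may report more compounds than this note shows. Statements on the series, on what has been measured and on what is new or still open speak of the compounds shown alone.

Among the measured compounds shown here, in an assay on membranes from lung (Cavia porcellus) for binding affinity to cysteinyl leukotriene receptor (Homo sapiens) (a lower number here means a stronger inhibitor, a higher number a weaker inhibitor), compound 2 `C#CCCCCCCCCCCc1ccccc1C(SCCC(=O)O)SCCC(=O)O` gives 141 nM, the only number in the set so far. Compound 1 `CCCCc1ccccc1C(SCCC(=O)O)SCCC(=O)O` gives only a limit there, > 20000 nM. For the measured compounds named here, the one measured step is an at least 140-fold lower number from compound 1 to compound 2 (2.15 log units; beyond the scatter), with one of the two values sitting at the limit of > 20000 nM in this assay, at which 1 of the 2 values shown sits. Compound 3 `CCCCc1ccc(CCCCc2ccccc2C(SCCC(=O)O)SCCC(=O)O)cc1` carries the change (4-butylphenyl in place of oct-7-yn-1-yl on a saturated chain carbon, four bonds along the chain from an aromatic carbon). Going by the values given here, no measured step replaces one chain by another at this position; the single step shows only that adding a chain there gives a large gain. The exchange is therefore expected to move the number little, a 1.3-fold higher number from compound 2 to compound 3 (0.11 log units; within the scatter), and compound 3 is estimated at 180 nM, between 40 nM and 800 nM.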

Compound 3, inhibition constant: 4230 nM
Compound 3: middle estimate off by 24-fold (1.37 log units), on the low side, and the stated range ends below it.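

In this assay this position does not treat all added chains alike: oct-7-yn-1-yl and 4-butylphenyl clearly part (a 30-fold higher number from compound 2 to compound 3 (1.48 log units; beyond the scatter)). 4-butylphenyl still improves on hydrogen (an at least 4.7-fold lower number from compound 1 to compound 3 (0.67 log units; beyond the scatter)), but that step rests on a limit for compound 1: (the limit of > 20000 nM in this assay, at which 1 of the 3 values shown sits).

Which part of the exchange carries the loss stays open, since the triple bond leaves, the aromatic ring enters and the heavy-atom count changes all at once. A plain octyl chain or a 4-butylcyclohexyl group would help to separate these changes.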